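Pyridin-3-yl to pyridin-4-yl on a shared core

The compounds below may be only part of what the source reports. "The series", "measured", "known", "first", "only" and "open" are said of these compounds alone.

compound 1 `CCCCNc1nc(NCCCC)c2cc(OC)c(OC)cc2n1`: 3670 nM
compound 2 `CCCCNc1nc(NCCCOCC)nc2cc(OC)c(OC)cc12`: 4460 nM
compound 3 `CCCCNc1nc(NCc2cccnc2)nc2cc(OC)c(OC)cc12`: 11100 nM

All three numbers come from an ADME assay on L6 cells (Rattus norvegicus) for cytotoxicity, read by fluorescence and resazurin assay, with a stated time of 70 h; on this read-out higher numbers stand for weaker inhibition and lower numbers for stronger inhibition. Compound 3 stands highest, at 11100 nM, which makes it the weakest inhibitor of the three. The next structure, compound 4 `CCCCNc1nc(NCc2ccncc2)nc2cc(OC)c(OC)cc12`, differs from it in one group: pyridin-4-yl in place of pyridin-3-yl on a saturated chain carbon bound to a nitrogen on an aromatic ring. The two have the same atoms, joined differently.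

Within the data shown here, no measured pair makes this exact swap. The closest evidence is the pair of steps that bring in pyridin-3-yl, a 3.0-fold higher number from compound 1 to compound 3 (0.48 log units; beyond the scatter) and a 2.5-fold higher number from compound 2 to compound 3 (0.40 log units; beyond the scatter). Both are modest, and each replaces a whole chain group rather than exchanging one pyridine form for another. Changing the chain itself gave only a 1.2-fold higher number from compound 1 to compound 2 (0.08 log units; within the scatter). On this evidence, no shift beyond the scatter is expected in this assay, in either direction. The expected size is a 1.1-fold lower number from compound 3 to compound 4 (0.05 log units; within the scatter), which remains an estimate. For compound 4 the estimated value is 10000 nM, with an expected range from 4800 nM to 21000 nM.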

Compound 4, half-maximal inhibitory concentration: 11000 nM
Compound 4: the middle estimate sits 1.1-fold (0.04 log units) below what was measured; the range from low to high includes it.
By their numbers in this assay, from the lowest: compounds 1 and 2 (each within the scatter of the next); then compounds 4 and 3 (each within the scatter of the next).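

In this assay, the step from one pyridine form to the other is a 1.0-fold lower number from compound 3 to compound 4 (0.00 log units; within the scatter), so on a saturated chain carbon bound to a nitrogen on an aromatic ring, pyridin-3-yl and pyridin-4-yl cannot be told apart on this read-out. Until now, only pyridin-3-yl had been compared with the chains at this place; pyridin-4-yl gives a 2.5-fold higher number from compound 2 to compound 4 (0.39 log units; beyond the scatter) and a 3.0-fold higher number from compound 1 to compound 4 (0.48 log units; beyond the scatter), so among these compounds the rise over the two chains does not depend on which of the two pyridine forms is present. Nothing measured here offers an explanation for why the two forms read alike.

From the compounds shown here alone, what a plain phenyl ring, with carbon in place of the ring nitrogen, or pyridin-2-yl would give on this same carbon remains open, and either would show whether the ring nitrogen counts at all. Also open, going by these compounds, is whether the rise over the chains needs an aromatic ring, a question that a saturated ring such as piperidin-4-yl at this place could help to answer.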